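A few compounds are considered here, and "the series" means these few. Any claim that something is new, unique, unknown or untested is made for them only; others in the source may bear on it.

Working notes on the series in an assay on cell membranes for displacement of a labelled ligand from corticotropin-releasing factor receptor 1 (Rattus norvegicus); on this read-out higher numbers stand for weaker inhibition and lower numbers for stronger inhibition. Compound 1 `CCC(CC)Nc1nc(C)nc2c(-c3ccc(OC)cc3)c(C)nn12` gives 3.8 nM. Compound 2 `CCN(CC)c1nc(C)nc2c(-c3c(C)cc(OC)cc3OC)c(C)nn12` gives 1.2 nM, and compound 3 `CCN(CC)c1nc(C)nc2c(-c3ccc(OC)c(C)c3C)c(C)nn12` gives 38.6 nM. Compound 2 thus stands at the lowest of the three numbers; the nearest neighbour is compound 1, whose number lies higher by a margin beyond the usual scatter, and the furthest is compound 3, higher again by a margin far beyond the scatter. Among the measured compounds shown here, no pair of measured compounds differs in only one place, so the measured set does not isolate any single change on its own. Compound 4 `CCC1CCCCN1c1nc(C)nc2c(-c3c(C)cc(OC)cc3OC)c(C)nn12` differs from compound 2 by 2-ethylpiperidin-1-yl in place of diethylamino on an aromatic carbon, the rest of the molecule being that of compound 2. For this exchange no step beyond the scatter is expected in this assay, in either direction. The estimate for compound 4 in this assay is 2 nM, with a range from 0.6 nM to 8 nM. This corresponds to an expected step of a 1.7-fold higher number from compound 2 to compound 4 (0.22 log units; within the scatter).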

Compound 4, half-maximal inhibitory concentration: 3.26 nM
Compound 4: the middle estimate sits 1.6-fold (0.21 log units) below what was measured; measured number inside the range.
By their numbers in this assay, from the lowest: compound 2; then compounds 4 and 1 (each within the scatter of the next); then compound 3.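

In this assay, among the compounds shown here, the step of a 2.7-fold higher number from compound 2 to compound 4 (0.43 log units; beyond the scatter) is the first single-place comparison, and it is a modest loss for 2-ethylpiperidin-1-yl in place of diethylamino. The position, on an aromatic carbon between two ring nitrogen atoms, therefore still tolerates a group with a six-membered non-aromatic ring and more heavy atoms, with compound 4 at 3.26 nM in this assay. No measurement available here bears on the origin of this step.

The compounds shown do not separate the contribution of the ring from that of the ethyl group, and plain piperidin-1-yl or morpholin-4-yl at this position would address that. From the compounds shown here alone, whether the same exchange gives a similar step on the differently substituted aromatic group of compound 3 also stays open.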